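A few compounds are considered here, and "the series" means these few. Any claim that something is new, unique, unknown or untested is made for them only; others in the source may bear on it.

Compound 1 `Nc1nc(-c2ccc(Cl)cc2)c(CC(=O)O)s1` carries an amino group on its five-membered core. In an in vitro functional assay on HEK285-7 cells for antagonist activity at prostaglandin D2 receptor 2 (Homo sapiens), read by BRET and beta-arrestin recruitment (a higher number here means a larger maximal response, a lower number a smaller maximal response), compound 1 gives 50%. Within the data shown here, compound 2 `O=C(O)Cc1sc(CS(=O)(=O)c2ccc(Cl)cc2)nc1-c1ccc(Cl)cc1` is the only other compound measured; in this assay compound 2 gives 30%. Of these two numbers compound 1 stands highest, and the gap to compound 2 lies beyond the usual scatter of this kind of measurement.

The next compound, compound 3 `O=C(O)Cc1sc(CSc2ccccc2)nc1-c1ccc(Cl)cc1`, keeps the core of compound 1 and changes one place: (phenylsulfanyl)methyl in place of amino on an aromatic carbon. Among the measured compounds shown here, no measured pair shows this particular exchange, so its effect can only be guessed from what the two known values suggest. The loss of the amino group, replaced by a much larger (phenylsulfanyl)methyl group, is expected to lower the maximal response, because compound 2 gives 30%. Compound 2 also departs from compound 1 at that same place. The step from compound 1 to compound 3 is therefore estimated as a number 17 percentage points lower from compound 1 to compound 3 (beyond the scatter), a drop beyond the scatter. For compound 3 the expected value in this assay is 33%, most likely between 18% and 50%.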

Compound 3, largest response reached (reported as efficacy), in percent of the reference or control that the assay uses: 50%
Beside the measured number, compound 3's estimate is 17 percentage points below it; the measured number falls inside the stated range.
By their numbers in this assay, from the lowest: compound 2; then compounds 1 and 3 (each within the scatter of the next).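

In this assay, placing (phenylsulfanyl)methyl instead of amino on this aromatic carbon, next to the ring nitrogen and next to the ring sulfur, gives no change at the digits printed from compound 1 to compound 3 (within the scatter). Among these compounds, this is the first single-place step read at this position, and it shows that the maximal response can hold while a lone nitrogen gives way to a group of 8 heavy atoms carrying a six-membered aromatic ring and 0 hydrogen-bond donors, so in this pair neither the size of the group nor the amino hydrogens set the read-out. Nothing available explains why the response holds across so large an exchange.

The compounds shown leave open which part of the new group matters, since the sulfur and the phenyl ring enter together. A phenoxymethyl group, with oxygen in place of sulfur, and a plain methyl group, with no ring at all, on the same carbon would begin to separate the contributions of the linking atom and the ring.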